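The compounds below may be only part of what the source reports. "The series", "measured", "known", "first", "only" and "open" are said of these compounds alone.

Measured compounds:
compound 1, `Cn1c(=O)[nH]c2c(cnn2-c2cc(Cl)cc(Cl)c2)c1=N`: 29%
compound 2, `Cn1c(=O)[nH]c2c(cnn2-c2cccc([N+](=O)[O-])c2)c1=N`: 2%
compound 3, `Cn1c(=O)[nH]c2c(cnn2-c2ccccc2F)c1=N`: 8%

These three share one core and differ only in the aryl group attached to it. In an assay on membranes from brain for binding affinity to adenosine receptor A1 (Rattus norvegicus), read by radioligand binding, tested at 20 uM (a lower number here means less inhibition, a higher number more inhibition at the concentration tested (going by the name of the read-out)), compound 1 gives the highest of the three numbers, and compound 3 stands second of the three. The nearest value to compound 3 is that of compound 2, lower but within the scatter, so the two cannot be ordered; the furthest is that of compound 1, higher and beyond the scatter.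

Compound 4, `Cn1c(=O)[nH]c2c(cnn2-c2ccccc2Br)c1=N`, has not yet been measured. It differs from compound 3 by bromo in place of fluoro on an aromatic carbon. Among the compounds with values here, no measured pair in this set shows the effect of such an exchange, so the size of the step is not known from the data. Because compound 3 sits near the low end with 8%, compound 4 is expected to give a value close to it, with at most a modest step in either direction, a number 5 percentage points higher from compound 3 to compound 4 (within the scatter) being the expected step. The estimate for compound 4 in this assay is 13%, between 2% and 32%.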

Compound 4, a percentage reported as inhibition, at one concentration (the size of the read-out at that concentration, not a potency): 6%
The estimate for compound 4 lay 7 percentage points above the measured number; low and high end bracket the measured number.
By their numbers in this assay, from the lowest: compounds 2, 4 and 3 (each within the scatter of the next); then compound 1.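

Bromo in place of fluoro on an aromatic carbon, ortho to a large group, is the first exchange in this set that can be read as a step: in this assay it gives a number 2 percentage points lower from compound 3 to compound 4 (within the scatter). At this position, then, the two halogens cannot be told apart in this measurement, and the size of the halogen atom's exchange shows no readable effect on the number. Nothing in the data bears on why this is so.

On these data alone, it remains open whether a group of another kind at this position, such as an amine, a methoxy group or a carboxylic acid, would give a number beyond the scatter of these two. As far as these compounds go, it also remains open whether the same exchange of fluoro for bromo would behave alike on another carbon of the ring.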